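The source may report more compounds than this note shows. Statements on the series, on what has been measured and on what is new or still open speak of the compounds shown alone.

Measured in an assay for inhibition of Amine oxidase [flavin-containing] B (Homo sapiens), read by fluorescence and spectrophotometry, using microsomes, with stated times of 30 min and 20 min; on this read-out higher numbers stand for weaker inhibition and lower numbers for stronger inhibition:
Compound 1, `N#Cc1ccc(C2=NCCN2c2cnccn2)cc1`: 17200 nM
Compound 2, `O=c1ccc(-c2ccccc2)nn1Cc1noc(-c2ccc(C3=NCCN3)cc2)n1`: 608 nM
Compound 3, `c1ccc(OCc2noc(-c3ccc(C4=NCCN4)cc3)n2)cc1`: 9980 nM

Compound 3 stands second highest of these three numbers. Its nearest neighbour is compound 1, whose number lies within the usual scatter of compound 3, so the two cannot be told apart. Compound 2 gives a much lower number, and that gap lies well beyond the scatter.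

Compound 4, `Clc1ccc(-c2noc(-c3ccc(C4=NCCN4)cc3)n2)cc1Cl`, is not yet measured. It differs from compound 3 in one place: 3,4-dichlorophenyl in place of phenoxymethyl on an aromatic carbon. In words, 3,4-dichlorophenyl takes the place of phenoxymethyl on an aromatic carbon of the five-membered ring that carries the shared core.

Within the data shown here, no measured pair shows this exact change, so the expectation rests on the three numbers above. Among the measured compounds shown here, compound 2 shows that a different large group at this same position can give a far lower number than compound 3, but no single step connects it to compound 4. A moderate move toward a lower number is expected in this assay, with wide uncertainty. The estimated step of a 3.3-fold lower number from compound 3 to compound 4 (0.52 log units; beyond the scatter) therefore points downward. Compound 4 is expected to give about 3000 nM, within 500 nM to 15000 nM.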

Compound 4, half-maximal inhibitory concentration: 12 nM
Compound 4: the middle estimate sits 250-fold (2.40 log units) above what was measured; the whole stated range lies above it.
By their numbers in this assay, from the lowest: compound 4; then compound 2; then compounds 3 and 1 (each within the scatter of the next).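

In this assay, among these compounds, the group on this aromatic carbon of the five-membered ring can move the number much further than the earlier compounds showed: placing 3,4-dichlorophenyl there instead of phenoxymethyl gives an 830-fold lower number from compound 3 to compound 4 (2.92 log units; beyond the scatter). The step is striking since both groups have the same count of heavy atoms and each holds one six-membered aromatic ring of carbon only, so that count alone does not separate them; they differ in that phenoxymethyl brings an oxygen and a hydrogen-bond acceptor, while 3,4-dichlorophenyl brings two chlorine atoms and no acceptor. No measurement shown here explains why the change has so large an effect.

The single change replaces the whole group, so the compounds shown leave open how much of the step goes with losing phenoxymethyl and how much goes with gaining the two chlorine atoms. A plain phenyl group or a phenyl group carrying one chlorine at this same place would help divide the step, while an amine or a carboxylic acid on the ring of the entering group would test how far such a change is tolerated.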